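This account rests on a few compounds, and the source may have more. Where it says the series, first, only, none or still open, it means among the compounds named here.

Measured compounds:
compound 1 `CC(C)c1cccc(C(C)C)c1NC(=O)NC(=O)N(Cc1ccccc1)Cc1ccccc1` — 1040 nM
compound 2 `CCCCCCCCCCCCC(C)(C)OC(=O)NC(=O)Nc1c(C(C)C)cccc1C(C)C` — 65 nM
compound 3 `CCCCCCOC(=O)NC(=O)Oc1c(C(C)C)cccc1C(C)C` — 53 nM

In an assay on microsomes from intestine for inhibition of acyl-CoA:cholesterol acyltransferase (Oryctolagus cuniculus) (a higher number here means a weaker inhibitor, a lower number a stronger inhibitor), compound 3 has the lowest of the three numbers. Compound 2, with its long branched chain, gives 65 nM, a value that lies within the scatter of compound 3, so the two cannot be told apart. Compound 1 gives 1040 nM, a clearly higher number that lies beyond the scatter.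

Compound 4 `CCCCCCCCCCCCCCCCCCOC(=O)NC(=O)Oc1c(C(C)C)cccc1C(C)C` extends the chain of compound 3: the change is dodecyl in place of hydrogen on a saturated chain carbon, six bonds along the chain from an oxygen next to a carbonyl group. For the measured compounds named here, no measured pair shows this particular step. What the numbers do show is that compound 2 carries a long chain and gives 65 nM, close to compound 3. That speaks for a small step, in no clear direction and probably not beyond the scatter. The step of a 1.0-fold higher number from compound 3 to compound 4 (0.02 log units; within the scatter) is expected to be small. Compound 4 is therefore expected to give about 55 nM, with a range from 20 nM to 150 nM.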

Compound 4, half-maximal inhibitory concentration: 1000 nM
Estimate against measurement, compound 4: 18-fold (1.26 log units) below; the measured number lies above the stated range.
By their numbers in this assay, from the lowest: compounds 3 and 2 (each within the scatter of the next); then compounds 4 and 1 (each within the scatter of the next).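

In this assay, this position does not accept every extension: placing dodecyl in place of hydrogen on a saturated chain carbon, six bonds along the chain from an oxygen next to a carbonyl group, gives a 19-fold higher number from compound 3 to compound 4 (1.28 log units; beyond the scatter) and so costs a large part of the inhibition. The chain at this point therefore matters to the result, and a chain that gives a low number cannot be assumed to keep it when dodecyl is added. No measurement shown here accounts for this loss, so the step stands as an observation without an explanation. Going by these compounds, whether a shorter addition, such as a butyl group, would keep the low number stays open, as does the outcome for a chain ending in an amine or a carboxylic acid. This single step gives the size of one change and does not establish a trend with chain length.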